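Moving a fluoro group around one aromatic ring

This account rests on a few compounds, and the source may have more. Where it says the series, first, only, none or still open, it means among the compounds named here.

Measured so far:
compound 1, `O=C1/C(=C/c2ccccc2)CCc2ccc(O)cc21`, 710 nM
compound 2, `O=C1/C(=C/c2ccccc2F)CCc2ccc(O)cc21`, 1350 nM

Both numbers come from a functional assay on RAW264.7 cells (Mus musculus) for inhibition; on this read-out higher numbers stand for weaker inhibition and lower numbers for stronger inhibition. Compound 1 holds the lower of the two, but the step of a 1.9-fold higher number from compound 1 to compound 2 (0.28 log units; within the scatter) stays within the scatter, so the pair cannot be ranked. Compound 3, `O=C1/C(=C/c2ccc(F)cc2)CCc2ccc(O)cc21`, differs from compound 1 by fluoro in place of hydrogen on an aromatic carbon. Among the measured compounds shown here, the only measured step that bears on this change, a 1.9-fold higher number from compound 1 to compound 2 (0.28 log units; within the scatter), also puts a fluoro group in place of hydrogen on that same ring and did not shift the number beyond the scatter. The same is expected here: the step of a 1.1-fold higher number from compound 1 to compound 3 (0.05 log units; within the scatter) is estimated to stay within the scatter. Compound 3 is therefore expected to give about 800 nM, within 300 nM to 2200 nM.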

Compound 3, half-maximal inhibitory concentration: 840 nM
Compound 3: middle estimate off by 1.1-fold (0.02 log units), on the low side; low and high end bracket the measured number.
By their numbers in this assay, from the lowest: compounds 1, 3 and 2 (each within the scatter of the next).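

Fluoro para to a large group gives a 1.2-fold higher number from compound 1 to compound 3 (0.07 log units; within the scatter) in this assay, so a second fluoro placement on this ring also stays inside the scatter. Alongside a 1.9-fold higher number from compound 1 to compound 2 (0.28 log units; within the scatter), this means neither placement can be told apart from the hydrogen of compound 1, and a single fluoro on this ring has produced no readable change at either position. No outside measurement speaks to a cause for this result. As far as these compounds go, what a methoxy group, an amine or a carboxylic acid would do at this position remains open.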